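Swapping the furan for a phenylethenyl arm on the ring

The compounds below may be only part of what the source reports. "The series", "measured", "known", "first", "only" and "open" are said of these compounds alone.

Compound 3 `O=CCN1N=C(c2ccc3ccccc3c2)CC1c1ccco1` stands second highest of the three numbers recorded in a functional assay on OVCAR cells (Homo sapiens) for cytotoxicity, read by sulforhodamine B assay, with a stated time of 48 h (a lower number here means a stronger inhibitor, a higher number a weaker inhibitor), where compound 3 gives 18000 nM. Its two neighbours are close: compound 2 `O=CCN1N=C(c2ccc3ccccc3c2)CC1c1cccc(Cl)c1Cl` gives 15100 nM, and compound 1 `O=CCN1N=C(c2ccc3ccccc3c2)CC1c1ccccc1` gives 21500 nM. For the measured compounds named here, the steps that bear on the new change are a 1.2-fold lower number from compound 1 to compound 3 (0.08 log units; within the scatter) and a 1.2-fold higher number from compound 2 to compound 3 (0.08 log units; within the scatter), and likewise a 1.4-fold lower number from compound 1 to compound 2 (0.15 log units; within the scatter); none of the three swaps at this saturated ring carbon moved the number beyond the scatter. Compound 4 `O=CCN1N=C(c2ccc3ccccc3c2)CC1/C=C/c1ccccc1` differs from compound 3 by 2-phenylethenyl in place of furan-2-yl on a saturated ring carbon. Since a 1.2-fold lower number from compound 1 to compound 3 (0.08 log units; within the scatter) was flat, compound 4 is expected to show no step beyond the scatter, no change at the digits printed from compound 3 to compound 4 (within the scatter). Compound 4 is therefore estimated at 18000 nM, within 7000 nM to 45000 nM.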

Compound 4, half-maximal inhibitory concentration: 18100 nM
Estimate against measurement, compound 4: 1.0-fold (0.00 log units) below, and the stated range covers the measured number.
By their numbers in this assay, from the lowest: compounds 2, 3, 4 and 1 (each within the scatter of the next).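

In this assay, the 2-phenylethenyl arm gives a 1.0-fold higher number from compound 3 to compound 4 (0.00 log units; within the scatter), alongside a 1.2-fold higher number from compound 2 to compound 4 (0.08 log units; within the scatter) and a 1.2-fold lower number from compound 1 to compound 4 (0.07 log units; within the scatter). All four groups on this saturated ring carbon, now including one with a double bond outside aromatic rings, thus stand within the scatter of one another. Nothing measured here offers a reason for this flat result. Still open, as far as these compounds go, is whether an amine or a carboxylic acid on this carbon would give a step beyond the scatter, and whether replacing the formylmethyl group on the shared core would do so.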